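The source may report more compounds than this note shows. Statements on the series, on what has been measured and on what is new or still open speak of the compounds shown alone.

Two measured compounds frame this account. Compound 1, `CCOc1ccc(NC(=O)c2cn(-c3ccccc3)nc2-c2ccc(OC)cc2)cc1`, gives 1100 nM in a functional assay on MCF7 cells (Homo sapiens) for cytotoxicity, read by MTT assay, with a stated time of 48 h; on this read-out lower numbers stand for stronger inhibition and higher numbers for weaker inhibition. Among the measured compounds shown here, compound 2, `O=C(Nc1ccc(Br)cc1)c1cn(-c2ccccc2)nc1-c1ccc(Cl)cc1`, gives 5310 nM in this assay, which is the highest of the two numbers known so far; its nearest neighbour is compound 1, whose number is lower by a margin that lies beyond the scatter of this kind of measurement. For the measured compounds named here, no single-point step between the two measured compounds exists, since they differ in more than one place, so their two values can only be set side by side.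

Compound 3, `CCOc1ccc(NC(=O)c2cn(-c3ccccc3)nc2-c2ccc(Cl)cc2)cc1`, is the unmeasured compound. It differs from compound 2 in one place: ethoxy in place of bromo on an aromatic carbon. Compound 3 shares its ethoxy anilide portion with compound 1 and its chloro-substituted aryl with compound 2, so it stands between the two measured structures. The number for compound 3 is expected to fall below that of compound 2, with an estimated step of a 2.7-fold lower number from compound 2 to compound 3 (0.42 log units; beyond the scatter) in this assay. Compound 3 is therefore estimated at 2000 nM, within a range from 700 nM to 6000 nM.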

Compound 3, half-maximal inhibitory concentration: 560 nM
For compound 3 the middle estimate is 3.6-fold (0.55 log units) above the measured one, outside the stated range (below it).
By their numbers in this assay, from the lowest: compounds 3 and 1 (each within the scatter of the next); then compound 2.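

In this assay, the group on the anilide ring proves to be a strong handle: with the chloro-substituted aryl unchanged, ethoxy in place of bromo, para to a large group, gives a 9.5-fold lower number from compound 2 to compound 3 (0.98 log units; beyond the scatter) and so separates this pair far more clearly than the two earlier compounds could, since they differed in more than one place. The other change, chloro in place of methoxy on an aromatic carbon with the ethoxy anilide unchanged, gives a 2.0-fold lower number from compound 1 to compound 3 (0.29 log units; within the scatter) and stays within the scatter, so no difference between these two aryl substituents can be read from this pair. Nothing measured here explains why the change from 4-bromophenyl to 4-ethoxyphenyl carries so much weight.

As far as these compounds go, it remains open whether ethoxy itself matters or whether a shorter or longer ether, such as methoxy or butoxy, or an amine on the same aromatic carbon would serve equally. From the compounds shown here alone, the large step also rests on a single pair, so whether it would recur with methoxy on the other aryl is unknown.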